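From Methoxy to Bromo on the Aromatic Ring

This account rests on a few compounds, and the source may have more. Where it says the series, first, only, none or still open, it means among the compounds named here.

Compound 1 `CCOC(=O)c1csc2nc(CN3CCN(C)CC3)c(-c3ccc(C)cc3)n12`: 43900 nM
Compound 2 `CCOC(=O)c1csc2nc(CN3CCN(C)CC3)c(-c3ccc(OC)cc3)n12`: 35100 nM

In a functional assay on HeLa cells (Homo sapiens) for antiproliferative activity, read by MTT assay, with a stated time of 72 h (a lower number here means a stronger inhibitor, a higher number a weaker inhibitor), compound 2 gives 35100 nM, level with compound 1 within the scatter. Compound 3 `CCOC(=O)c1csc2nc(CN3CCN(C)CC3)c(-c3ccc(Br)cc3)n12` keeps the shared core but carries bromo in place of methoxy on an aromatic carbon, para to a large group (bromo in place of methoxy on an aromatic carbon). For the measured compounds named here, only one measured step bears on this change: a 1.3-fold lower number from compound 1 to compound 2 (0.10 log units; within the scatter), where methoxy took the place of methyl on that same carbon. As far as these compounds go, one small step is thin evidence, and bromo itself is untested here. No shift beyond the scatter is therefore expected in this assay. The expected change is a 1.1-fold higher number from compound 2 to compound 3 (0.03 log units; within the scatter). The estimate for compound 3 is 38000 nM, with an expected range from 18000 nM to 80000 nM.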

Compound 3, half-maximal inhibitory concentration: 55400 nM
Beside the measured number, compound 3's estimate is 1.5-fold (0.16 log units) below it; measured number inside the range.
By their numbers in this assay, from the lowest: compounds 2, 1 and 3 (each within the scatter of the next).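

In this assay, bromo on this aromatic carbon stays within the scatter of both earlier groups: there is a 1.6-fold higher number from compound 2 to compound 3 (0.20 log units; within the scatter) and a 1.3-fold higher number from compound 1 to compound 3 (0.10 log units; within the scatter). Methyl, methoxy and bromo, para to a large group, therefore cannot be told apart here, although this change swaps two heavy atoms for one and removes a hydrogen-bond acceptor. No measurement shown explains how closely these numbers sit. As far as these compounds go, whether an amine or a carboxylic acid on this carbon would give a step beyond the scatter remains open.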